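The compounds below may be only part of what the source reports. "The series", "measured", "known", "first", "only" and "open" are said of these compounds alone.

Measured compounds:
Compound 1, `Cc1cc2nc(-c3cccc(Oc4ccccc4)c3)cc(-c3ccccc3)c2cc1C`, gives 5840 nM in a functional assay on G-361 cells (Homo sapiens) for inhibition, read by MTT assay, with a stated time of 24 h; a lower number here means a stronger inhibitor, a higher number a weaker inhibitor.
Compound 2, `N#Cc1ccc2nc(-c3cccc(Oc4ccccc4)c3)cc(-c3ccccc3)c2c1`, gives 2150 nM in this assay.
Compound 3, `Clc1ccc2nc(-c3cccc(Oc4ccccc4)c3)cc(-c3ccccc3)c2c1`, gives 12000 nM in this assay.

Compound 3 therefore gives the highest number of the three, and so is the weakest inhibitor among them, since its gaps to compound 1 and to compound 2 both lie beyond the usual scatter. For the measured compounds named here, the one single-point step measured so far is a 5.6-fold higher number from compound 2 to compound 3 (0.75 log units; beyond the scatter), a modest change that went beyond the scatter.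

The next compound, compound 4, `Brc1ccc2nc(-c3cccc(Oc4ccccc4)c3)cc(-c3ccccc3)c2c1`, differs from compound 3 in one place: bromo in place of chloro on an aromatic carbon. Going by the values given here, no measured step swaps one halogen for another at this position, so the measured step from compound 2 to compound 3 bears on it only loosely, by showing that this position can shift the number. With nothing more to go on, the change in this assay is expected to stay within the scatter, with no clear direction. Compound 4 is therefore estimated at 12000 nM, in a range from 5000 nM to 30000 nM. This estimate means a step of no change at the digits printed from compound 3 to compound 4 (within the scatter), which is expected to be small.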

Compound 4, half-maximal inhibitory concentration: 14600 nM
Compound 4: the middle estimate sits 1.2-fold (0.09 log units) below what was measured; the measured number falls inside the stated range.
By their numbers in this assay, from the lowest: compound 2; then compound 1; then compounds 3 and 4 (each within the scatter of the next).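

In this assay, bromo in place of chloro on this aromatic carbon gives a 1.2-fold higher number from compound 3 to compound 4 (0.09 log units; within the scatter), so the two halogens cannot be told apart at this position. The earlier compounds shown here showed a gap between cyano and only one halogen, whereas a 6.8-fold higher number from compound 2 to compound 4 (0.83 log units; beyond the scatter) shows a gap beyond the scatter for a second halogen as well, so the lower number of compound 2 stands apart from both halogen compounds and not from chloro alone. Nothing available here explains why the cyano compound differs from the two halogen compounds.

The compounds shown leave open whether the lower number belongs to cyano alone or would also appear with other groups on this carbon, such as an amine, a carboxylic acid, an amide or a methoxy group. They also leave open whether fluoro or iodo would match chloro and bromo, and whether the gap between cyano and the halogens would hold if the phenoxy-bearing or phenyl parts of the shared core were changed.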